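The source may hold more compounds than are shown below. What is called first, only, known or untested is meant among the compounds shown, and "the series" means these compounds.

Measured in an in vitro ADME assay on microsomes from liver (Homo sapiens) for metabolic stability; a lower number here means slower removal, a higher number faster removal of the compound:
compound 1 `Fc1ccccc1Cc1nc(-c2nc(C(F)(F)F)n[nH]2)c2cccnn12`: "not determined" (no result reported)
compound 2 `NC(=O)c1n[nH]c(-c2nc(Cc3ccccc3F)c3ccccn23)n1`: < 8 mL.min-1.g-1 (a limit)
compound 3 `Fc1ncncc1Cn1nc(-c2nc(C(F)(F)F)n[nH]2)c2cccnc21`: < 11 mL.min-1.g-1 (a limit)

Compound 2 stands at a limit in this assay (< 8 mL.min-1.g-1) and has no single number. Compound 3 also gives only a limit (< 11 mL.min-1.g-1). Compound 1 has no result ("not determined" (no result reported)). Among the compounds with values here, the series therefore holds no exact value and no measured step between two compounds to set a scale.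

Compound 4 `CS(=O)(=O)c1n[nH]c(-c2nc(Cc3ccccc3F)c3ccccn23)n1` differs from compound 2 in one place, with methylsulfonyl in place of carbamoyl on an aromatic carbon of a five-membered aromatic ring with 3 nitrogen, between two ring nitrogen atoms (methylsulfonyl in place of carbamoyl on an aromatic carbon).

Within the data shown here, with no measured step to go on, no change beyond the scatter is expected in this assay. As far as these compounds go, this expectation starts from compound 2 (< 8 mL.min-1.g-1), whose value is a limit, so the true starting point is unknown and the estimate leans slightly towards faster removal. The expected step (a number no lower from compound 2 to compound 4 (the limit leaves the size open)) is small. For compound 4 the estimated clearance is 8 mL.min-1.g-1, with an expected range from 4 mL.min-1.g-1 to 18 mL.min-1.g-1, and the assay may again report only a limit.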

Compound 4, intrinsic clearance in microsomes: 11 mL.min-1.g-1
Estimate against measurement, compound 4: 1.4-fold (0.14 log units) below; the measured number falls inside the stated range.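

In this assay, within the data shown here, compound 4 gives 11 mL.min-1.g-1, the first exact number, so the aromatic carbon between two ring nitrogen atoms now has a measured reference point. Methylsulfonyl in place of carbamoyl gives an at least 1.3-fold higher number from compound 2 to compound 4 (0.13 log units; that floor lies within the scatter), which fixes only a floor for the step and leaves its true size unknown, so this change cannot yet be said to move the read-out beyond the usual scatter. Compound 2 supplies only a limit as the starting point of that step: the limit of < 8 mL.min-1.g-1 in this assay, at which 1 of the 4 values shown sits.

The compounds shown leave open how other groups on this same aromatic carbon, such as a carboxylic acid, a primary amine or a nitrile, would read in this assay on the core of compound 4. They also leave open whether trifluoromethyl would read differently from methylsulfonyl on that core, since compound 1 and compound 3 carry trifluoromethyl but each differs from compound 4 in more than one place, and so neither gives a step that can be read.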